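A replacement for the 1,3-thiazol-2-yl group of compound 2

A few compounds are considered here, and "the series" means these few. Any claim that something is new, unique, unknown or untested is made for them only; others in the source may bear on it.

Of the compounds shown here, two sharing one core have been measured so far in a functional assay on NCI-H460 cells (Homo sapiens) for cytotoxicity, read by MTT assay, with a stated time of 3 days (a higher number here means a weaker inhibitor, a lower number a stronger inhibitor), and their numbers lie close together. Going by the values given here, compound 1 `N#Cc1c(NN)nc(SCc2nc3ccccc3[nH]2)nc1-c1ccccc1` gives 2.6 nM and compound 2 `N#Cc1c(Nc2nccs2)nc(SCc2nc3ccccc3[nH]2)nc1-c1ccccc1` gives 3.37 nM so compound 2 stands within the usual scatter of its only measured neighbour. Compound 3 `N#Cc1c(NNC(N)=S)nc(SCc2nc3ccccc3[nH]2)nc1-c1ccccc1` comes next, with this change: a group of 4 heavy atoms (1 carbon, 2 nitrogen, 1 sulfur; no ring) in place of a group of 5 heavy atoms (3 carbon, 1 nitrogen, 1 sulfur; one five-membered aromatic ring with 2 hetero atoms), on a nitrogen on an aromatic ring and the shared core otherwise untouched.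

Among the compounds with values here, one measured step bears on this change, at the same nitrogen: a 1.3-fold higher number from compound 1 to compound 2 (0.11 log units; within the scatter) and the two groups involved there could not be told apart on the numbers. Within the data shown here, no measured compound carries the group that enters in compound 3, so this single step is thin evidence. Even so, it gives no ground for expecting a step beyond the scatter in either direction. The estimated step is a 1.1-fold lower number from compound 2 to compound 3 (0.05 log units; within the scatter) and it amounts to no expected real change. For compound 3 the expected value is 3 nM with an estimated range from 0.9 nM to 10 nM as the likely span.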

Compound 3, half-maximal inhibitory concentration: 3.37 nM
Compound 3: middle estimate off by 1.1-fold (0.05 log units), on the low side; the range from low to high includes it.
By their numbers in this assay, from the lowest: compounds 1, 2 and 3 (each within the scatter of the next).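

In this assay, the open-chain group of compound 3, which has no ring and carries a double bond outside aromatic rings, replaces the five-membered aromatic ring of the 1,3-thiazol-2-yl group on the same nitrogen, and the step reads no change at the digits printed from compound 2 to compound 3 (within the scatter) and stays within the scatter. Extending the amine nitrogen of compound 1 with this group gives a 1.3-fold higher number from compound 1 to compound 3 (0.11 log units; within the scatter), also within the scatter, so three different groups at this position, the amino group, the 1,3-thiazol-2-yl group and the open-chain group, now cannot be told apart on the numbers, where the earlier compounds offered only two groups and a single step. Nothing measured here accounts for this lack of separation among the three compounds.

Going by these compounds, whether a carboxylic acid or a longer alkyl chain at this nitrogen would also stay within the scatter remains open. The three compounds also leave unsettled how far this holds once the phenyl or the nitrile on the shared core is replaced, for instance by a methyl group or an amide.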